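Double-bond geometry in the linker and cytotoxicity

The compounds below may be only part of what the source reports. "The series", "measured", "known", "first", "only" and "open" are said of these compounds alone.

In an ADME assay on BHK cells (Mesocricetus auratus) for cytotoxicity, read by MTT assay (on this read-out lower numbers stand for higher toxicity in this test and higher numbers for lower toxicity in this test), compound 1 `OC[C@@H]1[C@@H](O)[C@H](O)[C@@H](O)CN1CCCCCCOc1ccc(C(F)(F)F)cc1` gives 470000 nM and compound 3 `CCC1CCC(OCCCCCCN2C[C@H](O)[C@@H](O)[C@H](O)[C@H]2CO)CC1` gives 475000 nM; these two values lie within the scatter of each other. Compound 2 `OC[C@@H]1[C@@H](O)[C@H](O)[C@@H](O)CN1CC/C=C/CCOc1cc(F)ccc1F` reaches only a limit of this assay, reported as > 500000 nM, so its position is known only as the limit of > 500000 nM in this assay, at which 1 of the 3 values shown sits. Compound 4 `OC[C@@H]1[C@@H](O)[C@H](O)[C@@H](O)CN1CC/C=C\CCOc1cc(F)ccc1F` is its direct counterpart: the two compounds have the same atoms and bonds and differ only in configuration as drawn: 1 of 5 stereo elements differ; a double bond is drawn E in compound 2 and Z in compound 4. For the measured compounds named here, no measured pair in the set differs in only one place, so no step size is available from this assay. For a change of double-bond geometry alone, with identical atoms and bonds, no shift beyond the scatter is expected in either direction, and the step from a number no higher from compound 2 to compound 4 (the limit leaves the size open) is expected to be flat. Compound 4 is therefore estimated at 500000 nM, within 250000 nM to 1000000 nM, most likely again at the limit.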

Compound 4, half-maximal cytotoxic concentration: > 500000 nM
Compound 4: a limit, no number (the forecaster's own chance of this, stated with the estimate: 65%); the middle value lies on the limit itself.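

Compound 2 and compound 4 both give a limit rather than a number, and no step can be read between them. The compounds shown leave open whether the E and Z double bonds differ in cytotoxicity at all.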